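Replacing a Small Selenium Group with a Longer Chain

The source may report more compounds than this note shows. Statements on the series, on what has been measured and on what is new or still open speak of the compounds shown alone.

In a functional assay on HepG2 cells (Homo sapiens) for inhibition, read by MTT assay, with a stated time of 48 h (on this read-out higher numbers stand for weaker inhibition and lower numbers for stronger inhibition), compound 3 `COc1ccc(N(C)c2nc(C)nc3ccccc23)cc1[Se]C` gives 17 nM, the lowest number of the three measured compounds. Compound 4 `COc1ccc(N(C)c2nc(C)nc3ccccc23)cc1OCC[Se]C#N` differs from it by a group of 6 heavy atoms (3 carbon, 1 nitrogen, 1 oxygen, 1 selenium; no ring) in place of a group of 2 heavy atoms (1 carbon, 1 selenium; no ring), on an aromatic carbon. Two measured compounds carry longer chains with selenium and a nitrile on that carbon: compound 1 `COc1ccc(N(C)c2nc(C)nc3ccccc23)cc1OCCC[Se]C#N` gives 1040 nM, and compound 2 `COc1ccc(N(C)c2nc(C)nc3ccccc23)cc1C(=O)OCC[Se]C#N` gives 890 nM. These two lie within the scatter, a 1.2-fold lower number from compound 1 to compound 2 (0.07 log units; within the scatter). The small group of compound 3 marks a large difference from both, a 61-fold lower number from compound 1 to compound 3 (1.79 log units; beyond the scatter) and a 52-fold lower number from compound 2 to compound 3 (1.72 log units; beyond the scatter). Compound 4 also carries such a chain, so it is expected to sit with those two. The expected step is large and upward, a 53-fold higher number from compound 3 to compound 4 (1.72 log units; beyond the scatter). Compound 4 is estimated at 900 nM, with an expected range from 350 nM to 2500 nM.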

Compound 4, half-maximal inhibitory concentration: 14 nM
The estimate for compound 4 lay 64-fold (1.81 log units) above the measured number; the whole stated range lies above it.
By their numbers in this assay, from the lowest: compounds 4 and 3 (each within the scatter of the next); then compounds 2 and 1 (each within the scatter of the next).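

The long chain by itself does not raise the number on this aromatic carbon: the step is a 1.2-fold lower number from compound 3 to compound 4 (0.08 log units; within the scatter), so the small group and the chain of compound 4 cannot be told apart here. The chain's exact form matters sharply, since shortening the chain gives a 74-fold lower number from compound 1 to compound 4 (1.87 log units; beyond the scatter), and replacing the ester-linked chain gives a 64-fold lower number from compound 2 to compound 4 (1.80 log units; beyond the scatter). No measurement shown explains these steps.

From the compounds shown here alone, it remains open whether the low number would hold with sulfur in place of selenium, or with an amine in place of the nitrile.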